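Replacing the 4-nitrophenyl group of compound 2

The source may report more compounds than this note shows. Statements on the series, on what has been measured and on what is new or still open speak of the compounds shown alone.

Measured so far in a functional assay on HeLa cells (Homo sapiens) for inhibition, read by MTT assay, with a stated time of 48 h; on this read-out lower numbers stand for stronger inhibition and higher numbers for weaker inhibition:
Compound 1 `COc1cc(/C=C2\SC(=O)N(CCNC(=O)Nc3c(C)n(C)n(-c4ccccc4)c3=O)C2=O)cc(OC)c1OC`: 15800 nM
Compound 2 `Cc1c(NC(=O)CN2C(=O)S/C(=C\c3ccc([N+](=O)[O-])cc3)C2=O)c(=O)n(-c2ccccc2)n1C`: 77200 nM

Compound 2 holds the higher of the two numbers in this assay, and compound 1 lies below it by more than the usual scatter. Compound 3 `Cc1cc(C)c(/C=C2\SC(=O)N(CC(=O)Nc3c(C)n(C)n(-c4ccccc4)c3=O)C2=O)c(C)c1` carries 2,4,6-trimethylphenyl in place of 4-nitrophenyl on a double-bonded chain carbon bound to a double-bonded ring carbon. Among the compounds with values here, no measured pair of compounds shows this change on its own. A moderate move toward lower numbers is expected, and the estimated step is a 2.0-fold lower number from compound 2 to compound 3 (0.31 log units; beyond the scatter). The expected value for compound 3 is 38000 nM, with an estimated range of 12000 nM to 100000 nM.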

Compound 3, half-maximal inhibitory concentration: 60900 nM
The estimate for compound 3 lay 1.6-fold (0.20 log units) below the measured number; low and high end bracket the measured number.
By their numbers in this assay, from the lowest: compound 1; then compounds 3 and 2 (each within the scatter of the next).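

In this assay, putting 2,4,6-trimethylphenyl in place of 4-nitrophenyl gives a 1.3-fold lower number from compound 2 to compound 3 (0.10 log units; within the scatter) and stays within the scatter. Within the data shown here, this is the first comparison of a single change at this position, and it shows that these two aromatic groups cannot be told apart here, although only 4-nitrophenyl carries hydrogen-bond acceptors. No measurement available here bears on this result. As far as these compounds go, it remains open whether an amine or a carboxylic acid on the aromatic ring at this position would shift the number beyond the scatter.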